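Changing the carbamoyl group of compound 3

A few compounds are considered here, and "the series" means these few. Any claim that something is new, unique, unknown or untested is made for them only; others in the source may bear on it.

Measured in a functional assay on SiHa cells (Homo sapiens) for antiproliferative activity, read by CCK-8 assay, with a stated time of 72 h; on this read-out higher numbers stand for weaker inhibition and lower numbers for stronger inhibition:
compound 1 `CCOc1ccc(-c2cncnc2-c2cc(OC)c(OC)c(OC)c2)cc1`: 640 nM
compound 2 `COc1cc(-c2ncncc2-c2ccc(OC(C)C)cc2)cc(OC)c1OC`: 9970 nM
compound 3 `COc1cc(-c2ncncc2-c2ccc(C(N)=O)cc2)cc(OC)c1OC`: > 100000 nM, a limit and not a number

Compound 3 stands at the limit of this assay, with > 100000 nM. Compound 4 `COc1cc(-c2ncncc2-c2ccc(B(O)O)cc2)cc(OC)c1OC` changes one place, an aromatic carbon para to a large group: a group of 3 heavy atoms (1 boron, 2 oxygen; no ring) in place of a group of 3 heavy atoms (1 carbon, 1 nitrogen, 1 oxygen; no ring), on an aromatic carbon. Among the compounds with values here, three measured steps concern this carbon: a 16-fold higher number from compound 1 to compound 2 (1.19 log units; beyond the scatter), an at least 150-fold higher number from compound 1 to compound 3 (2.19 log units; beyond the scatter) and an at least 10-fold higher number from compound 2 to compound 3 (1.00 log units; beyond the scatter). None of them shows the entering group, so they set no exact size for the new step. Given an at least 150-fold higher number from compound 1 to compound 3 (2.19 log units; beyond the scatter), the read-out clearly responds to this carbon, and a modest to large step toward a lower number is expected, though another limit remains possible. The estimated step is an at least 16-fold lower number from compound 3 to compound 4 (1.22 log units; beyond the scatter). The estimate for compound 4 is 6000 nM, expected within 500 nM to 70000 nM.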

Compound 4, half-maximal inhibitory concentration: 17500 nM
The estimate for compound 4 lay 2.9-fold (0.46 log units) below the measured number; low and high end bracket the measured number.
By their numbers in this assay, from the lowest: compound 1; then compounds 2 and 4 (each within the scatter of the next). At a limit, above all of these: compound 3.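

In this assay, the aromatic carbon para to a large group accepts the group of 3 heavy atoms (1 boron, 2 oxygen) far better than carbamoyl, with an at least 5.7-fold lower number from compound 3 to compound 4 (0.75 log units; beyond the scatter). An alkoxy group is therefore not needed here for a measurable value, since the comparison with isopropoxy gives a 1.8-fold higher number from compound 2 to compound 4 (0.24 log units; within the scatter). Ethoxy still keeps a clear lead, with a 27-fold higher number from compound 1 to compound 4 (1.44 log units; beyond the scatter).

As far as these compounds go, compound 3 carries only a limit, so the exact size of its step stays open: the limit of > 100000 nM in this assay, at which 1 of the 4 values shown sits. From the compounds shown here alone, whether an amine, a carboxylic acid or a longer alkoxy chain on this carbon would come closer to ethoxy also remains open.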